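The compounds below may be only part of what the source reports. "The series", "measured", "known", "first", "only" and "open" are said of these compounds alone.

Series notes. Compound 1 `CC(/C=N/Nc1ccc([N+](=O)[O-])cc1)=N\NC(=O)c1ccccc1` carries hydrogen at the position later varied; in an ADME assay on J774 cells (Mus musculus, strain BALB/c) for cytotoxicity, read by resazurin assay, with a stated time of 72 h (on this read-out higher numbers stand for lower toxicity in this test and lower numbers for higher toxicity in this test), compound 1 gives > 100000 nM, which is a limit of the assay rather than a number (the limit of > 100000 nM in this assay, at which 1 of the 3 values shown sits). Compound 2 `CC(/C=N/Nc1ccc([N+](=O)[O-])cc1)=N\NC(=O)c1ccc(N)cc1` gives 75000 nM in this assay. Compound 3 `CC(/C=N/Nc1ccc([N+](=O)[O-])cc1)=N\NC(=O)c1ccc(O)cc1` gives 51000 nM, the lowest of the two numbers, with compound 2 nearest and the pair inside the scatter a 1.5-fold lower number from compound 2 to compound 3 (0.17 log units; within the scatter). The steps from hydrogen at that carbon, an at least 1.3-fold lower number from compound 1 to compound 2 (0.12 log units; that floor lies within the scatter) and an at least 1.9-fold lower number from compound 1 to compound 3 (0.29 log units; that floor lies within the scatter), have floors that also sit inside the scatter, so no substituent so far has moved this read-out beyond noise. Compound 4 `CC(/C=N/Nc1ccc([N+](=O)[O-])cc1)=N\NC(=O)c1ccc(C(C)(C)C)cc1` carries tert-butyl in place of hydroxy on an aromatic carbon. Among the measured compounds shown here, no measured step exchanges hydroxy for tert-butyl; the nearest guides are the hydroxy step from compound 1 and the amino-to-hydroxy step, both small, so in this assay no step beyond the scatter is expected, if anything a drift back toward the region where compound 1 sits. For compound 4 the expected step is a 1.6-fold higher number from compound 3 to compound 4 (0.20 log units; within the scatter). Compound 4 is estimated at 80000 nM, between 35000 nM and 200000 nM, with a fair chance that only a limit is returned.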

Compound 4, half-maximal cytotoxic concentration: > 100000 nM
Compound 4 gave a limit, no number; the forecaster's own chance of this, stated with the estimate: 35%; at least 1.2-fold (0.09 log units) between middle value and limit.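

In this assay, among the compounds shown here, tert-butyl on this aromatic carbon, with its 4 heavy atoms and no hydrogen-bond donor or acceptor, brings no lower number, whereas the earlier compounds held only hydroxy and amino in place of hydrogen. Exchanging hydroxy gives (an at least 1.9-fold higher number from compound 3 to compound 4 (0.29 log units; that floor lies within the scatter)) and exchanging amino gives (an at least 1.3-fold higher number from compound 2 to compound 4 (0.12 log units; that floor lies within the scatter)), so the change points upward but no separation beyond the scatter is yet shown. Compound 4 returns a limit and not a number, and its step from compound 1, which also sits at a limit, cannot be read: the limit of > 100000 nM in this assay, at which 2 of the 4 values shown sit.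

Any difference between hydrogen and tert-butyl therefore stays hidden at the limit. Open, as far as these compounds go, is whether a carboxylic acid, a methoxy group or a longer alkyl chain at this carbon would return a number, and whether any group here moves the read-out beyond the scatter.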